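Notes on the core series: compound 1 toward compound 4

This account rests on a few compounds, and the source may have more. Where it says the series, first, only, none or still open, it means among the compounds named here.

Compound 1 `CCCC[S+]([O-])c1sc2nc(-c3nccs3)cc(-c3ccc(C(=O)N(C)C)cc3)c2c1N` is measured in an assay for inhibition of 15-hydroxyprostaglandin dehydrogenase [NAD(+)] (Homo sapiens), read by fluorescence, with a stated time of 15 min, in the presence of a further agent that is not named here (a higher number here means a weaker inhibitor, a lower number a stronger inhibitor), at 5.9 nM. Among the two numbers recorded, compound 1 holds the higher one, though its nearest neighbour compound 2 `CCCC[S+]([O-])c1sc2nc(-c3nccn3C)nc(-c3ccccc3)c2c1N` gives 3.7 nM in this assay and the gap between them sits within the usual scatter. Compound 3 `Nc1c(C(=O)O)sc2nc(-c3cccs3)cc(-c3ccccc3)c12` returns only a limit in this assay, > 7500 nM, and no number; that is the limit of > 7500 nM in this assay, at which 1 of the 3 values shown sits.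

The next compound, compound 4 `CCCC[S+]([O-])c1sc2nc(-c3nccs3)cc(-c3ccc(CNC(C)=O)cc3)c2c1N`, has not yet been measured in this assay. It differs from compound 1 at one place: acetamidomethyl in place of dimethylcarbamoyl on an aromatic carbon. Within the data shown here, no measured step of this kind exists, so the expectation rests on compound 1 alone. A small shift, weakening if anything but plausibly inside the scatter, is expected, a 1.5-fold higher number from compound 1 to compound 4 (0.18 log units; within the scatter). Compound 4 is therefore estimated at 9 nM in this assay, expected between 3 nM and 30 nM.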

Compound 4, half-maximal inhibitory concentration: 2.5 nM
The estimate for compound 4 lay 3.6-fold (0.56 log units) above the measured number; the whole stated range lies above it.
By their numbers in this assay, from the lowest: compounds 4, 2 and 1 (each within the scatter of the next, the first and the last beyond it). At a limit, above all of these: compound 3.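

In this assay, acetamidomethyl in place of dimethylcarbamoyl on this aromatic carbon gives a 2.4-fold lower number from compound 1 to compound 4 (0.37 log units; beyond the scatter), the first step read at this position. The position, para to a large group, therefore responds to how the same atoms are joined, and the form with the amide hydrogen gives the lower number. No measurement given here accounts for this step.

As far as these compounds go, it remains open whether the amide hydrogen or the changed attachment to the ring carries the step. From the compounds shown here alone, it also remains open whether an amine or a carboxylic acid at this position would keep the inhibition seen with compound 4.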